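Aryl swap on a pyrazole carboxylic acid core

The source may hold more compounds than are shown below. What is called first, only, known or untested is meant among the compounds shown, and "the series" means these compounds.

Compound 2 `Cc1nn(-c2nc(-c3ccc(Cl)c(Cl)c3)c(SC(C)C)s2)c(C(=O)O)c1-c1cccc(Cl)c1C`: 5100 nM
Compound 1 `Cc1nn(-c2nc(-c3ccc(Cl)c(Cl)c3)c(SC(C)C)s2)c(C(=O)O)c1-c1cncc(C#N)c1`: 20000 nM

Compound 2 stands as the lowest of the two numbers in a functional assay on BJAB cells (Homo sapiens) for antiproliferative activity, with a stated time of 4 days; a higher number here means that more compound is needed for the effect, a lower number that less compound is needed. Its nearest neighbour is compound 1, which gives 20000 nM in this assay, and the step of a 3.9-fold lower number from compound 1 to compound 2 (0.59 log units; beyond the scatter) separates them, a modest change that lies beyond the scatter. Compound 3 `COc1cc(C#N)cc(-c2c(C)nn(-c3nc(-c4ccc(Cl)c(Cl)c4)c(SC(C)C)s3)c2C(=O)O)c1` arises from compound 2 by 3-cyano-5-methoxyphenyl in place of 3-chloro-2-methylphenyl on an aromatic carbon. Within the data shown here, the only measured step that bears on this change is a 3.9-fold lower number from compound 1 to compound 2 (0.59 log units; beyond the scatter), where a nitrile-bearing aromatic ring was replaced by a chloro- and methyl-bearing one. The entering group in compound 3 again carries a nitrile, together with a methoxy group, so the step from compound 2 to compound 3 is expected to run in the opposite direction and to be of about the same size, though this rests on a single measured pair. For compound 3 a value of 12000 nM is therefore expected, within a range of 4000 nM to 36000 nM, which corresponds to an estimated step of a 2.4-fold higher number from compound 2 to compound 3 (0.37 log units; beyond the scatter).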

Compound 3, half-maximal effective concentration: 5200 nM
Compound 3: the middle estimate sits 2.3-fold (0.36 log units) above what was measured, within the range that was stated.
By their numbers in this assay, from the lowest: compounds 2 and 3 (each within the scatter of the next); then compound 1.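

In this assay, the exchange of 3-chloro-2-methylphenyl for 3-cyano-5-methoxyphenyl gives a 1.0-fold higher number from compound 2 to compound 3 (0.01 log units; within the scatter), so a nitrile on the aromatic ring at this position does not by itself go with the higher number of compound 1. The comparison with the other nitrile-bearing compound gives a 3.8-fold lower number from compound 1 to compound 3 (0.59 log units; beyond the scatter), which shows that two nitrile-bearing rings at this position can differ beyond the scatter. Nothing available explains these results in terms of a measured property of the groups.

The compounds shown leave open whether the methoxy group or the absence of the ring nitrogen of 5-cyanopyridin-3-yl accounts for the step to compound 3, as the two changes occur together. They also leave open how this position would respond to a phenyl ring carrying an amine or a carboxylic acid.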